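Aryl amine variation on the shared core: compound 4

A few compounds are considered here, and "the series" means these few. Any claim that something is new, unique, unknown or untested is made for them only; others in the source may bear on it.

Compound 3 `COc1cc(NC(=O)Nc2cc(Nc3ccc(C(C)(C)C)cc3)ncn2)cc(OC)c1` gives 32.7% in a functional assay on HCC827 cells (Homo sapiens) for inhibition, read by MTT assay, with a stated time of 48 h, tested at 10 uM (a lower number here means less inhibition, a higher number more inhibition at the concentration tested (going by the name of the read-out)), the lowest of the three numbers. Compound 1 `COc1cc(NC(=O)Nc2cc(Nc3ccc(OC)c(C)c3)ncn2)cc(OC)c1` gives 48.3% and compound 2 `COc1cc(NC(=O)Nc2cc(Nc3cccc(C(C)(C)C)c3)ncn2)cc(OC)c1` gives 48.7% in this assay; these two stand within the scatter of each other, a number 0.4 percentage points higher from compound 1 to compound 2 (within the scatter). Both steps onto the 4-(tert-butyl)phenyl compound fall beyond the scatter: a number 15.6 percentage points lower from compound 1 to compound 3 (beyond the scatter) and a number 16 percentage points lower from compound 2 to compound 3 (beyond the scatter). Compound 4 `COc1cc(NC(=O)Nc2cc(Nc3cc(F)ccc3OC)ncn2)cc(OC)c1` carries the change (5-fluoro-2-methoxyphenyl in place of 4-(tert-butyl)phenyl on a nitrogen on an aromatic ring). For the measured compounds named here, the two measured steps bear on it only through removal of the 4-(tert-butyl)phenyl; the entering group is matched by no measured compound, though compound 1 also carries a methoxy-bearing aryl, the 4-methoxy-3-methylphenyl. A modest rise in this assay is therefore expected, a number 12.3 percentage points higher from compound 3 to compound 4 (beyond the scatter). Compound 4 is estimated at 45%, with a range from 28% to 62%.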

Compound 4, a percentage reported as inhibition, at one concentration (the size of the read-out at that concentration, not a potency): 59%
Compound 4: middle estimate off by 14 percentage points, on the low side; low and high end bracket the measured number.
By their numbers in this assay, from the lowest: compound 3; then compounds 1 and 2 (each within the scatter of the next); then compound 4.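

With the 5-fluoro-2-methoxyphenyl on the nitrogen, this position gives a number above all three earlier compounds in this assay: a number 10.7 percentage points higher from compound 1 to compound 4 (beyond the scatter) and a number 10.3 percentage points higher from compound 2 to compound 4 (beyond the scatter) and a number 26.3 percentage points higher from compound 3 to compound 4 (beyond the scatter). The 4-methoxy-3-methylphenyl and 3-(tert-butyl)phenyl compounds therefore do not mark the top of the range at this position. Nothing measured here accounts for the rise.

As far as these compounds go, the fluoro and methoxy groups enter together, so the share of each remains open. Also open, from the compounds shown here alone, is how an aryl carrying an amine or a carboxylic acid would read here.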